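Swapping a halogenated aryl group for an ester in compound 4

The source may report more compounds than this note shows. Statements on the series, on what has been measured and on what is new or still open speak of the compounds shown alone.

In a functional assay on A549 cells (Homo sapiens) for inhibition, read by CCK-8 assay, with a stated time of 72 h, tested at 10 uM (on this read-out higher numbers stand for more inhibition of growth at the one concentration tested and lower numbers for less inhibition of growth), compound 1 `COC(=O)c1ccc(NC(=O)C2(C(=O)Nc3ccc(Nc4ncc5cc(C(=O)N(C)C)n(C6CCCC6)c5n4)cc3)CC2)cc1` gives 92% of inhibition, compound 2 `CN(C)C(=O)c1cc2cnc(Nc3ccc(NC(=O)C4(C(=O)Nc5ccc(Cl)cc5)CC4)cc3)nc2n1C1CCCC1` gives 101% of inhibition and compound 3 `CN(C)C(=O)c1cc2cnc(Nc3ccc(NC(=O)C4(C(=O)Nc5ccc(Cl)c(C(F)(F)F)c5)CC4)cc3)nc2n1C1CCCC1` gives 88.1% of inhibition. Among the measured compounds shown here, compound 3 stands apart from only one neighbour: the data show a number 12.9 percentage points lower from compound 2 to compound 3 (beyond the scatter) against compound 2 but a number 3.9 percentage points lower from compound 1 to compound 3 (within the scatter) against compound 1.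

Compound 4 `COC(=O)c1cccc(NC(=O)C2(C(=O)Nc3ccc(Nc4ncc5cc(C(=O)N(C)C)n(C6CCCC6)c5n4)cc3)CC2)c1` differs from compound 3 at an amide-type nitrogen whose other neighbour is a carbonyl carbon, with 3-(methoxycarbonyl)phenyl in place of 4-chloro-3-(trifluoromethyl)phenyl on an amide-type nitrogen on that nitrogen.

The closest guide is the step that put 4-chloro-3-(trifluoromethyl)phenyl in place of 4-(methoxycarbonyl)phenyl, which gave a number 3.9 percentage points lower from compound 1 to compound 3 (within the scatter) and so offers little reason to expect a large change when an ester-bearing group returns. For the measured compounds named here, the only step beyond the scatter, a number 12.9 percentage points lower from compound 2 to compound 3 (beyond the scatter) for adding trifluoromethyl, is modest. Going by the values given here, no measured pair compares 3-(methoxycarbonyl)phenyl with 4-(methoxycarbonyl)phenyl, so that part remains open. The expected step is a number 1.9 percentage points higher from compound 3 to compound 4 (within the scatter) and no shift beyond the scatter is anticipated. The estimate for compound 4 in this assay is 90% with an expected range of 76% to 102% for the coming measurement.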

Compound 4, percent growth inhibition at one concentration: 91%
For compound 4 the middle estimate is 1 percentage points below the measured one; the range from low to high includes it.
By their numbers in this assay, from the lowest: compounds 3, 4, 1 and 2 (each within the scatter of the next, the first and the last beyond it).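

In this assay, the ester can sit in either of the two printed placements on this phenyl group with no reading that separates them: 3-(methoxycarbonyl)phenyl in place of 4-(methoxycarbonyl)phenyl on the amide-type nitrogen gives (a number 1 percentage points lower from compound 1 to compound 4 (within the scatter)). The same nitrogen also accepts 3-(methoxycarbonyl)phenyl in place of 4-chloro-3-(trifluoromethyl)phenyl (a number 2.9 percentage points higher from compound 3 to compound 4 (within the scatter)) and in place of 4-chlorophenyl (a number 10 percentage points lower from compound 2 to compound 4 (within the scatter)), so the halogenated and ester-bearing groups compared here are not told apart by these steps, even though the two halogenated groups differ beyond the scatter. Nothing in the information available explains these readings.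

Because each reading comes from the one concentration tested, the compounds shown leave open whether they would differ at lower concentrations. They also leave open whether a carboxylic acid or an amine on this phenyl ring, in place of the methyl ester, would give inhibition of growth like that of the ester-bearing compound 1 and compound 4.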